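Swapping the Furan for a Pentyl Chain on the Amide

This account rests on a few compounds, and the source may have more. Where it says the series, first, only, none or still open, it means among the compounds named here.

Measured compounds in a physicochemical assay for lipophilicity, using the shake flask method, in phosphate buffer, measured as octanol-water partition, at pH 7.4; on this read-out lower numbers stand for lower lipophilicity and higher numbers for higher lipophilicity:
compound 1, `COc1cc(-c2cc(C(=O)O)c3ccccc3n2)ccc1OCC(=O)Nc1cccc(F)c1`: 1.6
compound 2, `COc1cc(-c2cc(C(=O)O)c3ccccc3n2)ccc1OCC(=O)NCc1ccco1`: -0.3

Among these two numbers compound 2 gives the lower one in this assay. Within the data shown here, the single measured step, a number 1.90 log units lower from compound 1 to compound 2 (beyond the scatter), shows how much the group on the amide nitrogen can move this read-out. Compound 3, `CCCCCCNC(=O)COc1ccc(-c2cc(C(=O)O)c3ccccc3n2)cc1OC`, differs from compound 2 by pentyl in place of furan-2-yl on a saturated chain carbon bound to an amide-type nitrogen. Among the measured compounds shown here, no measured step covers a furan-to-alkyl swap, so the direction rests on the structural change alone, and the measured step only suggests its possible size. A rise is expected, a number 1.80 log units higher from compound 2 to compound 3 (beyond the scatter), giving compound 3 an estimated 1.5, in the range 0.5 to 2.5.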

Compound 3, distribution coefficient: 1
Beside the measured number, compound 3's estimate is 0.50 log units above it; the range from low to high includes it.
By their numbers in this assay, from the lowest: compound 2; then compound 3; then compound 1.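

Pentyl in place of furan-2-yl on a saturated chain carbon bound to an amide-type nitrogen gives a number 1.30 log units higher from compound 2 to compound 3 (beyond the scatter) in this assay, so a ring-to-chain swap at this position also moves the number beyond the scatter. Hexyl in place of 3-fluorophenyl gives a number 0.60 log units lower from compound 1 to compound 3 (beyond the scatter), which places the chain compound between the two ring compounds, so having a ring here does not by itself fix the value. No measurement shown explains either shift. Still open, going by these compounds, is how a longer chain, or a hexyl chain ending in an amine, would read here.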